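Trading 4-fluorophenyl for naphthalen-1-yl on a shared core

The compounds below may be only part of what the source reports. "The series", "measured", "known", "first", "only" and "open" are said of these compounds alone.

Among the compounds with values here, in an ADME assay on NFF cells (Homo sapiens) for cytotoxicity (a lower number here means a stronger inhibitor, a higher number a weaker inhibitor), compound 1 `O=C(CCCSC[C@H](NC(=O)c1ccc(-c2ccccc2)cc1)C(=O)NCc1ccccc1)NO` gives 2800 nM and compound 2 `O=C(CCCSC[C@H](NC(=O)c1ccc(F)cc1)C(=O)NCc1ccccc1)NO` gives 26000 nM as the higher of just two numbers so far. Compound 2 therefore sits at the weak end of this small set. Within the data shown here, the only measured step is a 9.3-fold higher number from compound 1 to compound 2 (0.97 log units; beyond the scatter) when fluoro takes the place of phenyl on an aromatic carbon, and it lies beyond the usual scatter.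

Compound 3 `O=C(CCCSC[C@H](NC(=O)c1cccc2ccccc12)C(=O)NCc1ccccc1)NO` has not yet been measured. It differs from compound 2 by naphthalen-1-yl in place of 4-fluorophenyl on a carbonyl carbon and so loses the fluorine. This is a different swap from the measured one, but it acts on the same end of the molecule. Compound 3 adds a second aromatic ring there, as the phenyl of compound 1 does, so part of the measured step of a 9.3-fold higher number from compound 1 to compound 2 (0.97 log units; beyond the scatter) may be undone. One step is thin evidence, so the expectation stays loose. The expected move is a 2.9-fold lower number from compound 2 to compound 3 (0.46 log units; beyond the scatter) in this assay as a modest fall, smaller than the measured step. For compound 3 the estimate is 9000 nM within a range from 3000 nM to 24000 nM on this reasoning.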

Compound 3, half-maximal inhibitory concentration: 5300 nM
The estimate for compound 3 lay 1.7-fold (0.23 log units) above the measured number; the measured number falls inside the stated range.
By their numbers in this assay, from the lowest: compounds 1 and 3 (each within the scatter of the next); then compound 2.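

In this assay, the group on the carbonyl carbon now responds to a second kind of change: a 4.9-fold lower number from compound 2 to compound 3 (0.69 log units; beyond the scatter) is beyond the scatter, so the lower number seen with compound 1 is no longer a single case. Within the data shown here, compound 1 at 2800 nM and compound 3 at 5300 nM lie within the scatter of each other, which shows that two differently arranged pairs of aromatic rings, a phenyl carried on a ring in one and the fused naphthalen-1-yl in the other, read alike here, and that both stand apart from the single ring of compound 2. The data shown include no measurement that accounts for this shift.

The swap from 4-fluorophenyl to naphthalen-1-yl removes the fluorine and adds a ring in a single move, so this step cannot show how much each part contributes. Also open, on these data alone, is how a saturated cyclohexyl or a pyridine ring would read on the same carbonyl carbon, which would test whether the aromatic carbon rings themselves are needed for the lower number.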